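Amide nitrogen alkylation on the pyrazolyl-bearing core

The source may report more compounds than this note shows. Statements on the series, on what has been measured and on what is new or still open speak of the compounds shown alone.

Measured so far:
compound 1 `CC[C@@H]1C(=O)N(C)c2cnc(-n3ccc4cc(F)ccc43)nc2N1C1CCCC1` — "not active" (no number reported)
compound 2 `CCC1C(=O)N(C)c2cnc(-n3ccc4cc(C(N)=O)ccc43)nc2N1c1ccn(C)n1` — 39500 nM
compound 3 `CCCCNC(=O)c1ccc2c(ccn2-c2ncc3c(n2)N(C2CCCC2)[C@H](CC)C(=O)N3C)c1` — 1160 nM

Compound 2 stands at the high end of the two numbers available in a functional assay on A549 cells (Homo sapiens) for antiproliferative activity, read by CCK-8 assay, with a stated time of 72 h; on this read-out lower numbers stand for stronger inhibition of growth and higher numbers for weaker inhibition of growth; the nearest numbered neighbour, compound 3, sits well beyond the scatter on the low side, and compound 1 carries no number at all. Compound 3 differs from compound 2 in more than one place, so its value alone says nothing about any single change.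

Compound 4 `CCNC(=O)c1ccc2c(ccn2-c2ncc3c(n2)N(c2ccn(C)n2)C(CC)C(=O)N3C)c1` is the next entry. Relative to compound 2 the change is ethyl in place of hydrogen on an amide-type nitrogen.

Going by the values given here, no measured pair isolates this change, so the expected step rests only on the direction seen with compound 3, whose value in this assay is 1160 nM and which carries an alkyl group on the same amide nitrogen. A moderate step downward from compound 2 to compound 4, a 4.0-fold lower number from compound 2 to compound 4 (0.60 log units; beyond the scatter), is expected, with wide uncertainty. Compound 4 is estimated at 10000 nM, in the range 3000 nM to 40000 nM.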

Compound 4, concentration for 50% growth inhibition: 21700 nM
The estimate for compound 4 lay 2.2-fold (0.34 log units) below the measured number; low and high end bracket the measured number.
By their numbers in this assay, from the lowest: compound 3; then compounds 4 and 2 (each within the scatter of the next).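

In this assay, going by these compounds alone, ethyl in place of hydrogen on an amide-type nitrogen gives a 1.8-fold lower number from compound 2 to compound 4 (0.26 log units; within the scatter) and is the first single-place step in this set. On this evidence, carbamoyl to ethylcarbamoyl does not separate the two compounds on this read-out, so an ethyl group at this nitrogen is tolerated without a step beyond the scatter. Compound 3 differs from both compounds in more than one place, so this step cannot be used to account for its number.

On these data alone, it remains open whether a propyl chain, a cyclopropyl ring or a chain ending in an amine at this nitrogen would give a step beyond the scatter. As far as these compounds go, it is also open whether the ethyl step would hold with the cyclopentyl group of compound 3 on the core. No supporting data bear on the size of this step.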